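The compounds below may be only part of what the source reports. "The series", "measured", "known", "first", "only" and "open" are said of these compounds alone.

Compound 1, `COc1ccc(-c2nc(CSc3cccc(Br)c3)nc3ccsc23)cn1` — in an ADME assay on cells (Homo sapiens) for cytotoxicity, read by resazurin assay, with a stated time of 5 days (on this read-out lower numbers stand for higher toxicity in this test and higher numbers for lower toxicity in this test), compound 1 gives > 50000 nM, which is a limit of the assay and not a number.
Compound 2, `O=S(=O)(Cc1nc(-c2ccncc2)c2sccc2n1)c1cccc(Cl)c1` — in this assay compound 2 gives > 50000 nM, again a limit.
Compound 3, `COc1ccc(-c2nc(C[S+]([O-])c3cccc(Cl)c3)nc3ccsc23)cn1` — in this assay compound 3 gives > 50000 nM, also a limit.

Compound 2 therefore stands where every measured value of this set stands: at the limit of > 50000 nM in this assay, at which 3 of the 3 values shown sit. No compound shown has a read-out as a number, so no order among them can be drawn. Among the compounds with values here, the one step between compounds that differ in a single place, a step that the two limits leave unreadable from compound 1 to compound 3, is unreadable for the same reason.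

The unmeasured compound 4, `COc1ccc(-c2nc(CS(=O)(=O)c3cccc(Cl)c3)nc3ccsc23)cn1`, differs from compound 2 by 6-methoxypyridin-3-yl in place of pyridin-4-yl on an aromatic carbon. Within the data shown here, no measured step touches this change, and the only step recorded, from compound 1 to compound 3, concerns another part of the molecule and gives no size. What the data do show is that three compounds sharing the core of compound 2, with differing groups on the saturated chain carbon and on the aromatic carbon, all sit at the limit. The account therefore expects compound 4 to remain there as well, with a step that the limit leaves unreadable from compound 2 to compound 4 expected to be no step beyond the scatter. Compound 4 is estimated at 60000 nM, within 30000 nM to 150000 nM, most likely reported only as a limit.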

Compound 4, half-maximal cytotoxic concentration: > 10000 nM
Compound 4: a limit, no number (the forecaster's own chance of this, stated with the estimate: 85%); the middle value is on the limit's open side.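

Compound 2 and compound 4 both stand only as limits, so no step can be read between them for 6-methoxypyridin-3-yl in place of pyridin-4-yl. The compounds shown leave open at what concentration any of them would reach the half-maximal read-out in this assay, and whether any change among them shifts it.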